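An arylamino group in place of a cyclic amine

A few compounds are considered here, and "the series" means these few. Any claim that something is new, unique, unknown or untested is made for them only; others in the source may bear on it.

Of the compounds shown here, two have so far been measured in a functional assay on the whole organism (strain Wister albino) for inhibition, with Rattus norvegicus as the target, read by paw edema, with stated times of 1 h and 3 h, at a dose of 50 mg/kg by the intraperitoneal route; a higher number here means more inhibition at the dose given (going by the name of the read-out), a lower number less inhibition. Compound 1 `CCOC(=O)c1c(-c2ccc(Cl)c(Cl)c2)cc(-c2ccccc2)nc1N1CCCCC1` gives 46.3%. Compound 2 `CCOC(=O)c1c(-c2ccc(Cl)cc2)cc(-c2ccccc2)nc1N1CCN(C)CC1` gives 67.8%, the highest of the two numbers, and its gap to compound 1 lies beyond the scatter. Compound 3 `CCOC(=O)c1c(-c2ccc(Cl)cc2)cc(-c2ccccc2)nc1Nc1ccc(OC)cc1` has not yet been measured in this assay. It differs from compound 2 in one place: (4-methoxyphenyl)amino in place of 4-methylpiperazin-1-yl on an aromatic carbon. The group sits on an aromatic carbon next to the ring nitrogen, ortho to the ethoxycarbonyl group and meta to both the 4-chlorophenyl group and the phenyl group. Among the measured compounds shown here, no measured pair shows this change, so its direction rests on no data. In this assay the expected step is a number 9.8 percentage points lower from compound 2 to compound 3 (within the scatter), estimated to be a fall of modest size, likely within or just beyond the scatter. Compound 3 is therefore expected to give 58%, in a range from 40% to 75%.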

Compound 3, a percentage reported as inhibition, in the whole organism at one dose (the size of the read-out at that dose, not a potency): 68.8%
For compound 3 the middle estimate is 10.8 percentage points below the measured one; low and high end bracket the measured number.
By their numbers in this assay, from the lowest: compound 1; then compounds 2 and 3 (each within the scatter of the next).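

In this assay, exchanging 4-methylpiperazin-1-yl for (4-methoxyphenyl)amino gives a number 1 percentage points higher from compound 2 to compound 3 (within the scatter), so this place, on an aromatic carbon next to the ring nitrogen, accepts either group without a change that the read-out can separate at the dose given. The entering group brings a hydrogen-bond donor and an aromatic ring of carbon only, and the leaving group has neither, so a non-aromatic ring is not required here for this level of inhibition. Nothing available explains why the two groups read alike.

On these data alone, it remains open whether the methoxy group on the new ring matters, and whether a phenylamino group or a plain amino group at this place would read the same. Also open, as far as these compounds go, is whether replacing the ethoxycarbonyl group with a carboxylic acid would hold the inhibition seen here.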